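Does the mirror image of compound 2 behave alike?

The source may report more compounds than this note shows. Statements on the series, on what has been measured and on what is new or still open speak of the compounds shown alone.

In an ADME assay on HOS cells (Homo sapiens) for cytotoxicity (a higher number here means that more compound is tolerated, a lower number that less compound is tolerated), compound 2 `CN1CCC[C@@H](Cn2c(CN(C)[C@H]3CCCc4cccnc43)nc3ccccc32)C1` gives 3500 nM, level within the scatter with compound 1 `CN1CCC[C@@H](Cn2c(CN(C)[C@@H]3CCCc4cccnc43)nc3ccccc32)C1` at 2800 nM. Compound 3 `CN1CCC[C@H](Cn2c(CN(C)[C@@H]3CCCc4cccnc43)nc3ccccc32)C1` comes next: the two compounds have the same atoms and bonds and differ only in configuration as drawn: 2 of 2 stereo elements differ (all stereocentres are inverted: mirror images); a stereocentre at a saturated ring carbon is drawn R in compound 2 and S in compound 3; a stereocentre at a saturated ring carbon is drawn S in compound 2 and R in compound 3. Going by the values given here, one measured step bears on this change, and it rests on (the fact that compounds 1 and 2 differ only in the configuration as drawn). From the compounds shown here alone, that step, a 1.3-fold higher number from compound 1 to compound 2 (0.10 log units; within the scatter), inverted a single stereocentre, so no change beyond the scatter is expected in this assay, although inverting both stereocentres remains untested. The expected step is a 1.2-fold lower number from compound 2 to compound 3 (0.07 log units; within the scatter). Compound 3 is estimated at 3000 nM, with an expected range of 1500 nM to 6000 nM.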

Compound 3, half-maximal cytotoxic concentration: 3600 nM
For compound 3 the middle estimate is 1.2-fold (0.08 log units) below the measured one, and the stated range covers the measured number.
By their numbers in this assay, from the lowest: compounds 1, 2 and 3 (each within the scatter of the next).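

In this assay, inverting both stereocentres at once gives a 1.0-fold higher number from compound 2 to compound 3 (0.01 log units; within the scatter), so this pair of mirror images shows no difference beyond the scatter. Inverting only one stereocentre gives a 1.3-fold higher number from compound 1 to compound 3 (0.11 log units; within the scatter), a second single-centre change that also stays within the scatter. Each comparison isolates the drawn arrangement in space, with the atoms and bonds unchanged: the fact that compounds 2 and 3 differ only in the configuration as drawn

The remaining open stereochemical case is the mirror image of compound 1. Also open, from the compounds shown here alone, is whether changing the atoms themselves, such as adding a carboxylic acid or a longer chain to the shared core, would shift this number.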